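Bromo-to-methoxy exchange carried onto the second core

The source may report more compounds than this note shows. Statements on the series, on what has been measured and on what is new or still open speak of the compounds shown alone.

Three measured compounds share one core and a substituted benzyl arm. Compound 1 `COc1ccc2c(c1)/C(=C1/Nc3ccccc3/C1=N\O)C(=O)N2Cc1ccc(/C=C/C(=O)NO)cc1` carries a methoxy together with the 2-(hydroxycarbamoyl)ethenyl group; compound 2 `O=C(/C=C/c1ccc(CN2C(=O)/C(=C3\Nc4ccccc4\C3=N/O)c3cc(Br)ccc32)cc1)NO` carries a bromo with the same group; compound 3 `O=C(NO)c1ccc(CN2C(=O)/C(=C3\Nc4ccccc4\C3=N/O)c3cc(Br)ccc32)cc1` carries the bromo with hydroxycarbamoyl attached directly. In a functional assay on PC-3 cells (Homo sapiens) for cytotoxicity, read by colorimetric assay (a higher number here means a weaker inhibitor, a lower number a stronger inhibitor), compound 1 gives 30 nM, compound 2 gives 90 nM, and compound 3 gives 50 nM.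

The two cores differ by hydroxycarbamoyl in place of 2-(hydroxycarbamoyl)ethenyl on an aromatic carbon. That exchange produced a 1.8-fold lower number from compound 2 to compound 3 (0.26 log units; within the scatter), a step within the scatter, so compound 2 and compound 3 are not separated by this read-out.

The change under consideration is methoxy in place of bromo on an aromatic carbon. From compound 2 to compound 1 it reads methoxy in place of bromo on an aromatic carbon and produced a 3.0-fold lower number from compound 2 to compound 1 (0.48 log units; beyond the scatter). The same change is now applied on the other core: compound 4 `COc1ccc2c(c1)/C(=C1/Nc3ccccc3/C1=N\O)C(=O)N2Cc1ccc(C(=O)NO)cc1` differs from compound 3 by methoxy in place of bromo on an aromatic carbon. The place descriptions of the two changes match word for word, so this is the same change, not merely the same kind. For the measured compounds named here, only one earlier instance exists, and the transfer rests on that single step.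

Compound 4 is expected to shift by a 2.8-fold lower number from compound 3 to compound 4 (0.44 log units; beyond the scatter) in this assay. The expectation leans on compound 2 and compound 1, whose step was a 3.0-fold lower number from compound 2 to compound 1 (0.48 log units; beyond the scatter), with the core exchange itself within the scatter. For compound 4 the estimate in this assay is 18 nM, ranging from 8 nM to 40 nM.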

Compound 4, half-maximal inhibitory concentration: 30 nM
Beside the measured number, compound 4's estimate is 1.7-fold (0.22 log units) below it; low and high end bracket the measured number.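

In this assay, methoxy in place of bromo on the second core gives a 1.7-fold lower number from compound 3 to compound 4 (0.22 log units; within the scatter), and this step does not separate from the one on the first core: the same change on two cores in this assay, a 3.0-fold lower number (0.48 log units; beyond the scatter) from compound 2 to compound 1 and a 1.7-fold lower number (0.22 log units; within the scatter) from compound 3 to compound 4, 1.8-fold (0.26 log units) apart, within the scatter of two such steps. The exchange of the arm, read on the methoxy pair, gives no change at the digits printed from compound 1 to compound 4 (within the scatter), and it agrees equally with the same exchange on the bromo pair: the same change on two cores in this assay, a 1.8-fold lower number (0.26 log units; within the scatter) from compound 2 to compound 3 and no change at the digits printed (within the scatter) from compound 1 to compound 4, 1.8-fold (0.26 log units) apart, within the scatter of two such steps. The four compounds are therefore compatible with the change carrying across the two cores without a detectable dependence on the core, but they do not show a reliable effect of the change on both: the step lies beyond the scatter on one core and within it on the other, and two pairs cannot fix its size.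

From the compounds shown here alone, it remains open whether an amine or a fluoro on the same aromatic carbon would read like the bromo or the methoxy compounds, which would test whether the pattern extends past this single exchange. It also remains open whether a longer chain between the benzyl ring and the hydroxycarbamoyl group would stay as close as the two arms shown here.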